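The source may report more compounds than this note shows. Statements on the series, on what has been measured and on what is new or still open speak of the compounds shown alone.

Measured compounds:
compound 1 `CN(CC1CC1)CC1(O)CCN(CCCc2c[nH]c3ccc(-n4cnnc4)cc23)CC1` — 1.1 nM
compound 2 `OC1(CNCc2ccccc2)CCN(CCCc2c[nH]c3ccc(-n4cnnc4)cc23)CC1` — 2.2 nM

In a functional assay on CHO cells for agonist activity at 5-hydroxytryptamine receptor 1D (Homo sapiens), read by GTPgammaS binding (on this read-out lower numbers stand for an effect already at smaller amounts and higher numbers for an effect only at larger amounts of compound), compound 1 gives 1.1 nM and compound 2 gives 2.2 nM. Compound 2 stands at the higher of the two numbers, but the step of a 2.0-fold higher number from compound 1 to compound 2 (0.30 log units; within the scatter) is within the scatter, so the two compounds are not separated on this read-out.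

Compound 3 `CN(CC(C)(C)C)CC1(O)CCN(CCCc2c[nH]c3ccc(-n4cnnc4)cc23)CC1` is not yet measured. It differs from compound 2 by methyl(neopentyl)amino in place of benzylamino on a saturated chain carbon bound to a saturated ring carbon. Within the data shown here, the only measured step that bears on this exchange is a 2.0-fold higher number from compound 1 to compound 2 (0.30 log units; within the scatter), which replaced (cyclopropylmethyl)(methyl)amino at the same place with benzylamino and gave no change beyond the scatter. Compound 3 brings a methyl-bearing amino back at that position, with neopentyl in place of the cyclopropylmethyl of compound 1. On this basis no step beyond the scatter is expected in this assay, with a lean toward a number near compound 1.

For compound 3 the expected value in this assay is 1.5 nM, with a range of 0.5 nM to 5 nM, which is an expected step of a 1.5-fold lower number from compound 2 to compound 3 (0.17 log units; within the scatter).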

Compound 3, concentration for half-maximal effect: 1.6 nM
Beside the measured number, compound 3's estimate is 1.1-fold (0.03 log units) below it; measured number inside the range.
By their numbers in this assay, from the lowest: compounds 1, 3 and 2 (each within the scatter of the next).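

In this assay, the exchange of benzylamino for methyl(neopentyl)amino on a saturated chain carbon bound to a saturated ring carbon gives a 1.4-fold lower number from compound 2 to compound 3 (0.14 log units; within the scatter) and so does not separate two amines that differ in the six-membered aromatic ring and the hydrogen-bond donor. Tert-butyl in place of cyclopropyl on a saturated chain carbon bound to an amine nitrogen gives a 1.5-fold higher number from compound 1 to compound 3 (0.16 log units; within the scatter) and likewise leaves the compounds unseparated, so among these three compounds neither a ring in the amino group nor the amine hydrogen is needed for a number in this range. No measurement in hand speaks to the reason for this flat result.

The compounds shown leave open where this tolerance ends, since all three carry a basic-type amino nitrogen name only in the sense of an amine at this place. An amide or a carboxylic acid there, or a longer chain between the saturated ring carbon and the amine, would test that limit.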